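This account rests on a few compounds, and the source may have more. Where it says the series, first, only, none or still open, it means among the compounds named here.

Working notes on the series.

The shared core of compound 1 `O=C(NCc1ccccc1)c1c(O)c2cccnc2n(-c2ccccc2)c1=O` carries an amide whose nitrogen bears a benzyl group. In a functional assay on the whole organism for inhibition, with Rattus norvegicus as the target, read by cytopathic effect and paw edema, at a dose of 100 mg/kg by the oral route (a higher number here means more inhibition at the dose given (going by the name of the read-out), a lower number less inhibition), compound 1 gives 11.3%. Compound 2 `O=C(NN1CCOCC1)c1c(O)c2cccnc2n(-c2ccccc2)c1=O` has morpholin-4-yl on that nitrogen instead; in this assay compound 2 gives -26.2%, and the step of a number 37.5 percentage points lower from compound 1 to compound 2 (beyond the scatter) is the one large move in the set. Compound 3 `Cc1ccc(NC(=O)c2c(O)c3cccnc3n(-c3ccccc3)c2=O)cc1` carries 4-methylphenyl on the amide-type nitrogen and gives 2.2% in this assay. Compound 3 stands second highest of the three numbers, though the step of a number 9.1 percentage points lower from compound 1 to compound 3 (within the scatter) leaves it and compound 1 indistinguishable, while the step of a number 28.4 percentage points higher from compound 2 to compound 3 (beyond the scatter) separates it from compound 2.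

Compound 4 `Cc1cccc(NC(=O)c2c(O)c3cccnc3n(-c3ccccc3)c2=O)c1` is not yet measured in this assay. It differs from compound 3 in one place: 3-methylphenyl in place of 4-methylphenyl on an amide-type nitrogen. Going by the values given here, no measured step moves a substituent around an aromatic ring; the steps that bear on the amide-type nitrogen exchange whole groups, and of these only the one to morpholin-4-yl went beyond the scatter. A change of this kind, on a group already close in size and shape to the one it replaces, is expected to give no step beyond the scatter, a number 0.8 percentage points higher from compound 3 to compound 4 (within the scatter). Compound 4 is therefore estimated at 3%, with a range of -14% to 20%.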

Compound 4, a percentage reported as inhibition, in the whole organism at one dose (the size of the read-out at that dose, not a potency): 4.5%
Compound 4: the middle estimate sits 1.5 percentage points below what was measured; measured number inside the range.
By their numbers in this assay, from the lowest: compound 2; then compounds 3, 4 and 1 (each within the scatter of the next).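

Moving the methyl group, with 3-methylphenyl in place of 4-methylphenyl on an amide-type nitrogen, is the first exchange in the series that keeps the same atoms, and in this assay the step of a number 2.3 percentage points higher from compound 3 to compound 4 (within the scatter) shows no readable response to this change. The step of a number 6.8 percentage points lower from compound 1 to compound 4 (within the scatter) places the new aryl amide alongside the benzyl amide as well, while the step of a number 30.7 percentage points higher from compound 2 to compound 4 (beyond the scatter) sets it clearly apart from the morpholin-4-yl amide, so that among these four compounds only morpholin-4-yl stands apart at this position, and compounds 1, 3 and 4 form one group with no order among them. Nothing measured here accounts for the separation of morpholin-4-yl from the other groups or for the flat response to the methyl shift.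

From the compounds shown here alone, it remains open whether the flat response holds for ring groups other than methyl, such as methoxy, chloro or a carboxylic acid in the 3-position or 4-position of the phenyl group. Going by these compounds, it also remains open whether piperidin-1-yl or a longer chain such as 2-phenylethyl on the same nitrogen would read with morpholin-4-yl or with the aryl and benzyl amides.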